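Cytotoxicity notes: methoxy for trifluoromethyl on the aryl ring

The source may hold more compounds than are shown below. What is called first, only, known or untested is meant among the compounds shown, and "the series" means these compounds.

Three members of this series have been read in an ADME assay on HepG2 cells (Homo sapiens) for cytotoxicity, read by luminescence, CellTiter-Glo and ATP content, with a stated time of 72 h; on this read-out higher numbers stand for an effect only at larger amounts of compound and lower numbers for an effect already at smaller amounts. Compound 1 `COc1cccc(CNCCCNc2ccnc3cc(-c4ccc(C(F)(F)F)cc4)ccc23)c1O` gives 2210 nM and stands lowest of the three numbers, though both neighbours fall within the scatter of it: compound 2 `CC(C)(C)c1ccc(Oc2ccc3c(NCCCNCc4ccco4)ccnc3c2)cc1` gives 3100 nM and compound 3 `FC(F)(F)c1ccc(-c2ccc3c(NCCCNCc4ccco4)ccnc3c2)cc1` gives 3470 nM. Going by the values given here, the only single-site step among them, a 1.6-fold higher number from compound 1 to compound 3 (0.20 log units; within the scatter), changes the amine-side aryl group and stays within the scatter, so the read-out has so far been flat across the series.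

Compound 4 `COc1ccc(-c2ccc3c(NCCCNCc4cccc(OC)c4O)ccnc3c2)cc1` is not yet measured. It differs from compound 1 by methoxy in place of trifluoromethyl on an aromatic carbon. Among the compounds with values here, no measured step touches this position; the values of compound 2 and compound 3 are the nearest reference, and they sit close to each other without a direct step between them. With every measured change leaving the number within the scatter, the expectation for this change is the same: no step beyond the scatter in this assay, in either direction, as expressed by a 1.1-fold higher number from compound 1 to compound 4 (0.05 log units; within the scatter).

Compound 4 is therefore estimated at 2500 nM, with a likely range from 1200 nM to 5500 nM.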

Compound 4, half-maximal effective concentration: 1600 nM
Estimate against measurement, compound 4: 1.6-fold (0.19 log units) above; measured number inside the range.
By their numbers in this assay, from the lowest: compounds 4, 1, 2 and 3 (each within the scatter of the next, the first and the last beyond it).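

Going by these compounds alone, the first direct step at this position, a 1.4-fold lower number from compound 1 to compound 4 (0.14 log units; within the scatter), shows that in this assay 4-methoxyphenyl can take the place of 4-(trifluoromethyl)phenyl on the core of compound 1 without the number leaving the scatter. The change swaps trifluoromethyl, with no hydrogen-bond acceptor, for methoxy, with one, on an aromatic carbon para to a large group, and this difference in the substituent leaves no readable mark on this read-out, so both single-site steps now on hand, one at each end of the molecule, stay within the scatter. No measurement available bears on what lies behind this result.

Within the data shown here, whether the same exchange behaves alike with the furan-2-yl group of compound 3 in place of the 2-hydroxy-3-methoxyphenyl group of compound 1 remains open, since only one amine-side group carries the methoxy change here. Also open, on these data alone, is whether a nitrile, an amine or a carboxylic acid at this aromatic carbon, or a longer chain in place of the present one on the shared core, would move the number beyond the scatter.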